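Fluoro for ethyl on the fused ring of compound 1

The source may hold more compounds than are shown below. What is called first, only, known or untested is meant among the compounds shown, and "the series" means these compounds.

Values in a functional assay on CHO cells for antagonist activity at prostaglandin E2 receptor EP3 subtype (Homo sapiens), read by cAMP accumulation, with a stated time of 30 min (a lower number here means a stronger inhibitor, a higher number a weaker inhibitor), so far:
compound 1 `CCc1cccc2ccc(-c3ccc(C(/C=C4\OC(=O)NC4=O)(CC)CC)c(=O)[nH]3)cc12` gives 91 nM
compound 2 `CC(C)C(CC1C(=O)NC(=O)N1C)c1ccc(-c2ccc3cccc(F)c3c2)[nH]c1=O` gives 65 nM
compound 3 `CC(C)[C@@H](c1ccc(-c2ccc3cccc(F)c3c2)[nH]c1=O)[C@@H]1OC(=O)NC1=O` gives 610 nM

Compound 1 stands second highest of the three numbers in this assay. Its nearest neighbour is compound 2, whose number is lower by an amount within the usual scatter, so the two cannot be ordered. Compound 3 is furthest away, with a higher number beyond the scatter, and compound 3 also differs from compound 1 in more than one place, so nothing is computed between them.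

Among the compounds with values here, compound 4 `CCC(/C=C1\OC(=O)NC1=O)(CC)c1ccc(-c2ccc3cccc(F)c3c2)[nH]c1=O` is the direct analogue of compound 1 in which the only change is fluoro in place of ethyl on an aromatic carbon. The remaining parts of the shared core are unchanged.

Within the data shown here, no step between measured compounds bears on this exchange. Compound 2 and compound 3 carry the fluoro group but differ elsewhere, so they give no isolated reading of it. The expectation for the step of a 1.1-fold lower number from compound 1 to compound 4 (0.06 log units; within the scatter) is therefore a small one, in either direction, most likely none beyond the scatter. Compound 4 is expected to give 80 nM in this assay, with a range from 30 nM to 250 nM.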

Compound 4, half-maximal inhibitory concentration: 61 nM
Beside the measured number, compound 4's estimate is 1.3-fold (0.12 log units) above it; the range from low to high includes it.
By their numbers in this assay, from the lowest: compounds 4, 2 and 1 (each within the scatter of the next); then compound 3.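

In this assay the exchange of ethyl for fluoro on an aromatic carbon of the shared core gives a 1.5-fold lower number from compound 1 to compound 4 (0.17 log units; within the scatter), so compound 1 and compound 4 cannot be ordered. Within the data shown here, this is the first isolated reading of the exchange: with the remainder of the structure held constant, a group of 2 heavy atoms and a group of 1 heavy atom, ortho to a fused ring and meta to a fused ring, give numbers within the usual scatter of each other. The reading covers this pair alone, and no measurement on hand accounts for it.

The compounds shown leave open how an amine, a carboxylic acid, a methoxy group or a longer chain such as butyl would read on the same aromatic carbon, and so how far the range of groups accepted there extends beyond ethyl and fluoro. They also leave open whether the exchange would read the same way with the other side chains of the series, since no ethyl partner stands beside compound 2 or compound 3.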